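A few compounds are considered here, and "the series" means these few. Any claim that something is new, unique, unknown or untested is made for them only; others in the source may bear on it.

Compound 2, with the structure `COc1ccc(-n2cc3nc(C)nc(N)c3n2)cc1`, gives 38% in an assay on CHO cells for displacement of a labelled ligand from adenosine receptor A3 (Homo sapiens), read by scintillation counting, with a stated time of 60 min, tested at 1 uM; a higher number here means more inhibition at the concentration tested (going by the name of the read-out), a lower number less inhibition. Compound 1, `COc1ccc(-n2cc3nc(Cc4ccccc4)nc(N)c3n2)cc1`, gives 45% in the same measurement, and the change a number 7 percentage points lower from compound 1 to compound 2 (within the scatter) leaves the two within the scatter of each other; compound 2 simply has the lower of the two numbers. Compound 3, `COc1ccc(-n2cc3nc(C)nc(NC(=O)Nc4ccccc4)c3n2)cc1`, differs from compound 2 by phenylcarbamoyl in place of hydrogen on a nitrogen on an aromatic ring. Among the measured compounds shown here, no measured step touches this place, so the only step on record, a number 7 percentage points lower from compound 1 to compound 2 (within the scatter), offers no guide, and the expectation is uncertain. Compound 3 is estimated at 35%, with a range from 10% to 65%. The expected step is a number 3 percentage points lower from compound 2 to compound 3 (within the scatter).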

Compound 3, a percentage reported as inhibition, at one concentration (the size of the read-out at that concentration, not a potency): 1%
Compound 3: middle estimate off by 34 percentage points, on the high side, outside the stated range (below it).
By their numbers in this assay, from the lowest: compound 3; then compounds 2 and 1 (each within the scatter of the next).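

In this assay, among the compounds shown here, putting phenylcarbamoyl on this nitrogen gives a number 37 percentage points lower from compound 2 to compound 3 (beyond the scatter) and is the first change here to exceed the scatter. The earlier change on the chain carbon gave only a number 7 percentage points lower from compound 1 to compound 2 (within the scatter), so this nitrogen is the one place shown where a change clearly moves the read-out. Nothing measured here explains the drop.

The compounds shown leave open whether the loss follows from the phenyl ring or from the carbonyl on the nitrogen. An acetyl or a benzyl group at this nitrogen would help separate the two.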